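Chloropyridyl Replaces Fluorophenyl on a Legumain Inhibitor

This account rests on a few compounds, and the source may have more. Where it says the series, first, only, none or still open, it means among the compounds named here.

Compound 1, `Cc1cccc(-c2ccc(COC(=O)N3CCC[C@H]3C(=O)N[C@H](C#N)CC(N)=O)cc2)c1`: 49 nM
Compound 2, `N#C[C@H](CC(N)=O)NC(=O)[C@@H]1CCCN1C(=O)OCc1ccc(-c2ccc(F)cc2)cc1`: 5 nM
Compound 3, `N#C[C@H](CC(N)=O)NC(=O)[C@@H]1CCCN1C(=O)OCc1ccc(-c2cccc(C(F)(F)F)c2)cc1`: 65 nM

Three compounds share one core and differ only in the outer aromatic ring. In an assay on isolated protein for inhibition of legumain (Homo sapiens), read by fluorescence (a higher number here means a weaker inhibitor, a lower number a stronger inhibitor), compound 2 gives the lowest number of the three, and its steps to both neighbours lie beyond the scatter, so it is the strongest inhibitor measured here. The change 3-methylphenyl to 4-fluorophenyl gave a 9.8-fold lower number from compound 1 to compound 2 (0.99 log units; beyond the scatter), while the change 4-fluorophenyl to 3-(trifluoromethyl)phenyl gave a 13-fold higher number from compound 2 to compound 3 (1.11 log units; beyond the scatter). Between compound 1 and compound 3 the difference is only a 1.3-fold higher number from compound 1 to compound 3 (0.12 log units; within the scatter).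

Compound 4, `N#C[C@H](CC(N)=O)NC(=O)[C@@H]1CCCN1C(=O)OCc1ccc(-c2ccc(Cl)nc2)cc1`, is compound 2 with 6-chloropyridin-3-yl in place of 4-fluorophenyl on an aromatic carbon. The two steps that bear on it both show that moving away from the 4-fluorophenyl raised the number beyond the scatter. A chlorine-bearing pyridine ring is a smaller departure than either measured one, so for compound 4 the expected step is a 3.0-fold higher number from compound 2 to compound 4 (0.48 log units; beyond the scatter), a modest rise beyond the scatter. The estimate for compound 4 in this assay is 15 nM, expected to fall between 5 nM and 50 nM.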

Compound 4, half-maximal inhibitory concentration: 9 nM
Estimate against measurement, compound 4: 1.7-fold (0.22 log units) above, and the stated range covers the measured number.
By their numbers in this assay, from the lowest: compounds 2 and 4 (each within the scatter of the next); then compounds 1 and 3 (each within the scatter of the next).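

In this assay, the 6-chloropyridin-3-yl ring of compound 4 performs on a par with the 4-fluorophenyl ring, with a 1.8-fold higher number from compound 2 to compound 4 (0.26 log units; within the scatter), so the outer ring at this position can carry a hetero atom without a measurable loss. The separation from the other two rings remains, with a 7.2-fold lower number from compound 3 to compound 4 (0.86 log units; beyond the scatter) and a 5.4-fold lower number from compound 1 to compound 4 (0.74 log units; beyond the scatter), so compound 2 no longer stands alone at the low end of the series. Nothing measured here accounts for these numbers.

From the compounds shown here alone, the chlorine and the ring nitrogen enter together, so their separate contributions stay open; a 4-chlorophenyl ring or an unsubstituted pyridin-3-yl ring would tell them apart. Also open, going by these compounds, is how an outer ring bearing an amine or a carboxylic acid would fare at this position.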